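The source may hold more compounds than are shown below. What is called first, only, known or untested is meant among the compounds shown, and "the series" means these compounds.

Measured compounds:
Compound 1, `Nc1ncnc2c1nc(-c1ccccc1)n2[C@H]1C[C@H](O)[C@@H](COP(=O)(O)OP(=O)(O)OC[C@H]2OC(O)[C@H](O)[C@@H]2O)O1`: 3000 nM
Compound 2, `Nc1ncnc2c1nc(-c1ccccc1)n2[C@@H]1O[C@H](COP(=O)(O)OP(=O)(O)OC[C@H]2OC(O)[C@H](O)[C@@H]2O)[C@@H](O)[C@H]1O`: 11000 nM
Compound 3, `O=c1[nH]cnc2c1ncn2[C@@H]1O[C@H](COP(=O)(O)OP(=O)(O)OC[C@H]2OC(O)[C@H](O)[C@@H]2O)[C@@H](O)[C@H]1O`: "not active" (no number reported)

Within the data shown here, in an assay on HEK293 cells for antagonist activity at transient receptor potential cation channel subfamily M member 2 (Homo sapiens), read by patch clamp (on this read-out lower numbers stand for stronger inhibition and higher numbers for weaker inhibition), compound 1 gives 3000 nM and compound 2 gives 11000 nM; the only measured step, a 3.7-fold higher number from compound 1 to compound 2 (0.56 log units; beyond the scatter), changes a hydroxy for a hydrogen on a saturated ring carbon. Compound 3 stands apart: in this assay compound 3 was reported as "not active" (no number reported), so no number places it on the scale, and its bicyclic group differs from those of compounds 1 and 2.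

Compound 4, `Nc1nc(F)nc2c1ncn2[C@@H]1O[C@H](COP(=O)(O)OP(=O)(O)OC[C@H]2OC(O)[C@H](O)[C@@H]2O)[C@@H](O)[C@H]1O`, arises from compound 3 by a group of 11 heavy atoms (5 carbon, 5 nitrogen, 1 fluorine; one five-membered aromatic ring with 2 hetero atoms, one six-membered aromatic ring with 2 hetero atoms) in place of a group of 10 heavy atoms (5 carbon, 4 nitrogen, 1 oxygen; one five-membered aromatic ring with 2 hetero atoms, one six-membered aromatic ring with 2 hetero atoms), on a saturated ring carbon. No measured step touches the bicyclic group, so the step from compound 1 to compound 2 gives no guide to this exchange, and its size cannot be read from any shown pair. Compounds 1 and 2 show that this shared core can carry measurable inhibition in this assay, while compound 3 shows that it need not. Compound 4 is therefore expected to lie near 5000 nM, with a range from 1500 nM to 20000 nM, and a real chance that only a limit is reported.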

Compound 4, half-maximal inhibitory concentration: "not active" (no number reported)
Compound 4 has no reported number here; no gap can be computed for the estimate.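

In this assay compound 3 gives "not active" (no number reported) and compound 4 gives "not active" (no number reported), so no step can be read between them. No evidence shown bears on this result. The compounds shown leave open whether exchanging the bicyclic group changes inhibition at all.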